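The source may report more compounds than this note shows. Statements on the series, on what has been measured and on what is new or still open speak of the compounds shown alone.

Compound 1 `COc1cnc(-c2ccccn2)nc1NCc1ccccc1C(F)(F)F` gives 555 mL/min/kg in an in vitro ADME assay on microsomes from liver (Rattus norvegicus) for metabolic stability, read by LC-MS, tested at 0.05 uM; a higher number here means faster removal of the compound, a lower number slower removal. Compound 3 `COc1cnc(-c2ccccn2)nc1NCc1ccccc1` gives 387 mL/min/kg. Compound 2 `COc1cnc(-c2ccccn2)nc1C1CCCC1` gives > 1000 mL/min/kg, which is a limit of this assay and not a number.

Compound 2 therefore stands at the limit of > 1000 mL/min/kg in this assay, at which 1 of the 3 values shown sits, so no numbered step from it is known. Compound 4 `COc1cnc(-c2ccccn2)nc1N1CCCC1` differs from compound 2 by pyrrolidin-1-yl in place of cyclopentyl on an aromatic carbon. Among the compounds with values here, the only measured step, a 1.4-fold lower number from compound 1 to compound 3 (0.16 log units; within the scatter), concerns a different part of the molecule and does not bear on this exchange. Compounds 1 and 3, both carrying a nitrogen-linked group, sit at numbers, while compound 2 sits at the limit. The expected step is an at least 1.4-fold lower number from compound 2 to compound 4 (0.15 log units; that floor lies within the scatter). Compound 4 is estimated at 700 mL/min/kg, between 300 mL/min/kg and 1500 mL/min/kg.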

Compound 4, clearance: 987 mL/min/kg
For compound 4 the middle estimate is 1.4-fold (0.15 log units) below the measured one; the measured number falls inside the stated range.
By their numbers in this assay, from the lowest: compounds 3, 1 and 4 (each within the scatter of the next, the first and the last beyond it). At a limit, above all of these: compound 2.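

In this assay, pyrrolidin-1-yl in place of cyclopentyl on this aromatic carbon gives an at least 1.0-fold lower number from compound 2 to compound 4 (0.00 log units; that floor lies within the scatter). Compound 4 thus gives a readable number with a ring at this position, though the size of the step remains only a floor and shows no drop beyond the scatter. Compound 2 stays at a limit of the assay, which is not a number: the limit of > 1000 mL/min/kg in this assay, at which 1 of the 4 values shown sits.

The compounds shown leave open how morpholin-4-yl or an open-chain amine such as diethylamino would read at this position.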